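Trifluoromethyl in place of hydrogen: compound 4 from compound 3

The source may hold more compounds than are shown below. What is called first, only, known or untested is meant among the compounds shown, and "the series" means these compounds.

The series holds compound 1 `CNc1nc(C)c(C(=O)N/N=C/c2cccc(C(F)(F)F)c2)s1`, compound 2 `CNc1nc(C)c(C(=O)N/N=C/c2cc(C(F)(F)F)cc(C(F)(F)F)c2)s1`, compound 3 `Cc1nc(N(C)C(=O)NC(=O)c2c(F)cccc2F)sc1C(=O)N/N=C/c1cccc(C(F)(F)F)c1` and the unmeasured compound 4 `Cc1nc(N(C)C(=O)NC(=O)c2c(F)cccc2F)sc1C(=O)N/N=C/c1cc(C(F)(F)F)cc(C(F)(F)F)c1`. In a functional assay on A549 cells (Homo sapiens) for inhibition, read by MTT assay, with a stated time of 72 h (on this read-out lower numbers stand for stronger inhibition and higher numbers for weaker inhibition), compound 1 reaches only the limit > 100 ug/mL. Compound 2 likewise stops at the limit > 100 ug/mL in this assay. The change from compound 1 to compound 2, (trifluoromethyl in place of hydrogen on an aromatic carbon), therefore gives a step that the two limits leave unreadable from compound 1 to compound 2, which follows from the limit of > 100 ug/mL in this assay, at which 2 of the 3 values shown sit. Within the data shown here, compound 3 gives 30.3 ug/mL in this assay, the only number among the three. The difference between the cores of compound 1 and compound 3 is not broken down here. Compound 4 carries the same change, (trifluoromethyl in place of hydrogen on an aromatic carbon), at a place described in the same words. Because the earlier step rests on (the limit of > 100 ug/mL in this assay, at which 2 of the 3 values shown sit), its size offers no guide, so the expectation leans on compound 3 alone. Compound 4 is expected at 35 ug/mL, between 12 ug/mL and 100 ug/mL. The expected step is a 1.2-fold higher number from compound 3 to compound 4 (0.06 log units; within the scatter).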

Compound 4, half-maximal inhibitory concentration: 13 ug/mL
Compound 4: the middle estimate sits 2.7-fold (0.43 log units) above what was measured, and the stated range covers the measured number.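

In this assay, trifluoromethyl in place of hydrogen on the aromatic carbon gives a 2.3-fold lower number from compound 3 to compound 4 (0.37 log units; beyond the scatter), so on the core of compound 3 the change goes with stronger inhibition. The step from compound 1 to compound 2 cannot be read, so a comparison of the change across the two cores remains out of reach: the limit of > 100 ug/mL in this assay, at which 2 of the 4 values shown sit. The result therefore rests on one readable pair, and it shows neither that the change carries from one core to the other nor why the number moves.

The compounds shown leave open whether a nitrile, a chlorine atom or an amine on the same aromatic carbon would shift the number as trifluoromethyl does. They also leave open whether the step from compound 3 to compound 4 would hold on other cell lines.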